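The source may report more compounds than this note shows. Statements on the series, on what has been measured and on what is new or still open speak of the compounds shown alone.

Going by the values given here, compound 3 `c1cncc(CNC2CCN(CCCc3c[nH]c4ccc(-n5cnnc5)cc34)CC2)c1` stands second highest of the three numbers so far in an assay on CHO cells for displacement of a labelled ligand from 5-hydroxytryptamine receptor 1D (Homo sapiens); on this read-out lower numbers stand for stronger inhibition and higher numbers for weaker inhibition: compound 3 gives 35 nM, with compound 1 `O[C@H]1Cc2ccccc2C1NC1CCN(CCCc2c[nH]c3ccc(-n4cnnc4)cc23)CC1` nearest at 37 nM and compound 2 `CN(Cc1ccccc1)CC1CCN(CCCc2c[nH]c3ccc(-n4cnnc4)cc23)CC1` furthest at 0.9 nM. The step of a 1.1-fold lower number from compound 1 to compound 3 (0.02 log units; within the scatter) shows that exchanging one group on the amine nitrogen for another changed little, whereas a 41-fold lower number from compound 1 to compound 2 (1.61 log units; beyond the scatter) and a 39-fold higher number from compound 2 to compound 3 (1.59 log units; beyond the scatter) show that moving to a (benzyl(methyl)amino)methyl group on the saturated ring carbon brought a large gain.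

Compound 4 `C[C@H](NCC1CCN(CCCc2c[nH]c3ccc(-n4cnnc4)cc23)CC1)c1ccccc1` takes the same ring carbon position: ((1-phenylethyl)amino)methyl in place of ((pyridin-3-yl)methyl)amino on a saturated ring carbon. The entering group carries the methylene link seen in compound 2 but keeps a secondary amine as in compound 3, so the change bears on both large steps. A step of the same direction as a 39-fold higher number from compound 2 to compound 3 (1.59 log units; beyond the scatter) reversed is expected, though smaller, since the amine is not methylated; the expected step is an 8.8-fold lower number from compound 3 to compound 4 (0.94 log units; beyond the scatter). The estimate for compound 4 in this assay is 4 nM, within 1 nM to 15 nM.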

Compound 4, half-maximal inhibitory concentration: 4.4 nM
Compound 4: middle estimate off by 1.1-fold (0.04 log units), on the low side; the range from low to high includes it.
By their numbers in this assay, from the lowest: compound 2; then compound 4; then compounds 3 and 1 (each within the scatter of the next).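

In this assay, an 8.0-fold lower number from compound 3 to compound 4 (0.90 log units; beyond the scatter) and an 8.4-fold lower number from compound 1 to compound 4 (0.92 log units; beyond the scatter) show that a ((1-phenylethyl)amino)methyl group on the saturated ring carbon lowers the number while keeping a secondary amine, so the tertiary amine of compound 2 is not required for a value in the low nanomolar range. Even so, a 4.9-fold higher number from compound 2 to compound 4 (0.69 log units; beyond the scatter) shows that (1-phenylethyl)amino in place of benzyl(methyl)amino on the saturated chain carbon gives back part of that gain, so the two amines are not interchangeable at this position. Nothing measured here gives a reason for these steps.

The exchange between compound 2 and compound 4 moves a methyl group from the amine nitrogen to the carbon bearing the phenyl ring, so the two effects cannot be separated. On these data alone, a plain (benzylamino)methyl group, or a tertiary N-methyl-1-phenylethyl amine, would separate them, and the role of the defined stereocentre also remains open.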